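Aromatic Ring Replaces Ester Chain on the Carbonyl

The source may report more compounds than this note shows. Statements on the series, on what has been measured and on what is new or still open speak of the compounds shown alone.

Compound 1, `CC(=O)N1N=C(c2ccc(N3CCN(C)CC3)cc2)CC1c1ccc(N(C)C)cc1`, gives -1% in a functional assay on MDA-MB-231 cells (Homo sapiens) for inhibition, read by sulforhodamine B assay, tested at 10 uM; on this read-out higher numbers stand for more inhibition at the one concentration tested (going by the name of the read-out) and lower numbers for less inhibition.
Compound 2, `CN1CCN(c2ccc(C3=NN(C(=O)CCCl)C(c4ccc(N(C)C)cc4)C3)cc2)CC1`, gives 2.4%.
Compound 3, `COC(=O)CC(=O)N1N=C(c2ccc(N3CCN(C)CC3)cc2)CC1c1ccc(N(C)C)cc1`, gives -0.4%.

Compound 3 stands second highest of these three numbers, with compound 1 nearest to it (a number 0.6 percentage points higher from compound 1 to compound 3 (within the scatter)) and compound 2 furthest (a number 2.8 percentage points lower from compound 2 to compound 3 (within the scatter)), both gaps inside the scatter. Compound 4, `CN1CCN(c2ccc(C3=NN(C(=O)c4ccc(F)cc4)C(c4ccc(N(C)C)cc4)C3)cc2)CC1`, differs from compound 3 by 4-fluorophenyl in place of (methoxycarbonyl)methyl on a carbonyl carbon. Among the compounds with values here, every measured step so far changed only a group on a saturated chain carbon bound to the carbonyl carbon, and all three (a number 3.4 percentage points higher from compound 1 to compound 2 (within the scatter) included) stayed within the scatter; none brought an aromatic ring onto the carbonyl carbon itself. With nothing in these data pointing to a shift, the expected step is a number 1.4 percentage points higher from compound 3 to compound 4 (within the scatter), within the scatter. Compound 4 is therefore estimated at 1%, between -10% and 12%.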

Compound 4, a percentage reported as inhibition, at one concentration (the size of the read-out at that concentration, not a potency): 3.5%
Compound 4: middle estimate off by 2.5 percentage points, on the low side, and the stated range covers the measured number.
By their numbers in this assay, from the lowest: compounds 1, 3, 2 and 4 (each within the scatter of the next).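

Within the data shown here, for the first time, the group on the carbonyl carbon carries an aromatic ring, yet in this assay 4-fluorophenyl gives no step beyond the scatter against any of the three chains: a number 3.9 percentage points higher from compound 3 to compound 4 (within the scatter), a number 1.1 percentage points higher from compound 2 to compound 4 (within the scatter) and a number 4.5 percentage points higher from compound 1 to compound 4 (within the scatter). Across these four compounds, then, methyl, 2-chloroethyl, (methoxycarbonyl)methyl and 4-fluorophenyl on this carbon are not told apart by this read-out. Nothing measured here offers a reason for this. On these data alone, whether an amine or a carboxylic acid on this carbonyl carbon would move the number beyond the scatter stays open, as does the effect of any change elsewhere on the shared core.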